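The compounds below may be only part of what the source reports. "The series", "measured", "known", "first", "only" and "open" are said of these compounds alone.

Within the data shown here, in a physicochemical assay for solubility, read by HPLC, in simulated intestinal fluid, with a stated time of 16 h, tested at 125 ug/mL (on this read-out higher numbers stand for higher solubility and lower numbers for lower solubility), compound 1 `CNC(=O)c1cc(C(=O)NC2CC2)cn(Cc2cccc([C@@H](C)O)c2)c1=O` gives 495 ug/mL, the higher of the two values measured so far. Compound 2 `CNC(=O)c1cc(C(=O)NC2CCC2)cn(Cc2ccncc2)c1=O` gives 121 ug/mL in this assay, a gap that lies beyond the usual scatter. Compound 3 `CNC(=O)c1cc(C(=O)NC2CC2)cn(Cc2cccc3cc[nH]c23)c1=O` has not yet been measured; it differs from compound 1 in one place: 1H-indol-7-yl in place of 3-(1-hydroxyethyl)phenyl on a saturated chain carbon bound to an aromatic nitrogen. Among the measured compounds shown here, no measured pair shows this change, so its size is not known from the data. The step of a 4.1-fold lower number from compound 1 to compound 3 (0.62 log units; beyond the scatter) is expected to lower solubility beyond the scatter. Compound 3 is therefore estimated at 120 ug/mL, with a likely range from 40 ug/mL to 300 ug/mL.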

Compound 3, solubility: 11 ug/mL
Compound 3: the middle estimate sits 11-fold (1.04 log units) above what was measured; the measured number lies below the stated range.
By their numbers in this assay, from the lowest: compound 3; then compound 2; then compound 1.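

Replacing 3-(1-hydroxyethyl)phenyl with 1H-indol-7-yl on a saturated chain carbon bound to an aromatic nitrogen gives a 45-fold lower number from compound 1 to compound 3 (1.65 log units; beyond the scatter) in this assay, so solubility depends strongly on the group at this position. The two groups have the same count of 9 heavy atoms and 1 hydrogen-bond donor, so matching those counts did not preserve the value. No supporting evidence bears on the cause of this drop.

Because the change alters the ring system, the hydroxyl-bearing chain and the stereocentre at once, these compounds cannot separate their contributions. Going by these compounds, it also remains open where a phenyl group carrying an amine or a carboxylic acid would fall relative to compound 1 and compound 3.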